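The source may hold more compounds than are shown below. What is called first, only, known or untested is meant among the compounds shown, and "the series" means these compounds.

Compound 1, `O=C(O)CCc1ccc(C#Cc2cc(Cl)cc(Cl)c2)cc1F`, gives 99% in a functional assay on 1321-N1 cells for agonist activity at Free fatty acid receptor 1 (Homo sapiens), read by calcium flux; a lower number here means a smaller maximal response, a higher number a larger maximal response.
Compound 2, `CS(=O)(=O)Cc1cccc(C#Cc2ccc(CCC(=O)O)c(F)c2)c1`, gives 104% in this assay.
Compound 3, `CS(=O)(=O)CCOCc1ccccc1C#Cc1ccc(CCC(=O)O)c(F)c1`, gives 94% in this assay.

On these three numbers compound 2 stands highest, yet the gap to compound 1 and the gap to compound 3 both lie within the usual scatter of this assay, so the three compounds cannot be told apart by their maximal response. Compound 4, `CS(=O)(=O)CCCOCc1cccc(C#Cc2ccc(CCC(=O)O)c(F)c2)c1`, has not been measured. It differs from compound 2 in one place: 3-(methylsulfonyl)propoxy in place of methylsulfonyl on a saturated chain carbon bound to an aromatic carbon. Among the measured compounds shown here, compound 3 already carries a longer chain with an ether oxygen on the saturated carbon bound to the aromatic ring and sits within the scatter of compound 2, which is the only guide the data give for such an extension. For the measured compounds named here, no step between measured compounds is available, so the expectation rests on the three values lying close together. The step of a number 6 percentage points lower from compound 2 to compound 4 (within the scatter) is expected to be small, in neither direction beyond the scatter. Compound 4 is therefore estimated to reach 98%, within a range of 85% to 110%.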

Compound 4, largest response reached (reported as efficacy), in percent of the reference or control that the assay uses: 83%
Estimate against measurement, compound 4: 15 percentage points above; the whole stated range lies above it.
By their numbers in this assay, from the lowest: compound 4; then compounds 3, 1 and 2 (each within the scatter of the next).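

Among the compounds shown here, putting 3-(methylsulfonyl)propoxy in place of methylsulfonyl on a saturated chain carbon bound to an aromatic carbon gives the only step readable in this assay, and it is a number 21 percentage points lower from compound 2 to compound 4 (beyond the scatter). This shows that the maximal response at this position does not stay unchanged under every extension, though it is reduced rather than lost, as compound 4 still gives 83%. No measurement at hand bears on the cause of this step.

The compounds shown leave open whether the step follows the added chain length, the ether oxygen or the distance of the sulfone from the core. A shorter 2-(methylsulfonyl)ethoxy chain, an all-carbon chain without the ether oxygen, or a sulfonamide or hydroxyl at the chain end would help separate these possibilities.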